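Compound 4 and the Amine-Borne Phenyl Group

This account rests on a few compounds, and the source may have more. Where it says the series, first, only, none or still open, it means among the compounds named here.

Compound 1 `O=C(CN1CCN(c2ccccc2Cl)CC1)N1CCN(c2nnc(-c3ccccc3)c(-c3ccccc3)n2)CC1`: 263000 nM
Compound 2 `O=C(CN1CCN(c2ccc(Cl)cc2)CC1)N1CCN(c2nnc(-c3ccccc3)c(-c3ccccc3)n2)CC1`: 56300 nM
Compound 3 `COc1cccc(N2CCN(CC(=O)N3CCN(c4nnc(-c5ccc(C)cc5)c(-c5ccc(C)cc5)n4)CC3)CC2)c1`: 867000 nM

Of the compounds shown here, three have been measured in a functional assay on MCF7 cells (Homo sapiens) for cytotoxicity, read by MTT assay, with a stated time of 24 h; on this read-out higher numbers stand for weaker inhibition and lower numbers for stronger inhibition. Compound 3 stands highest of the three numbers; its nearest neighbour is compound 1, and compound 2 lies furthest from it. Going by the values given here, the one step between measured compounds that differ in a single place is a 4.7-fold lower number from compound 1 to compound 2 (0.67 log units; beyond the scatter), a modest change that nonetheless lies beyond the scatter.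

Compound 4 `Cc1ccc(-c2nnc(N3CCN(C(=O)CN4CCN(c5ccc([N+](=O)[O-])cc5)CC4)CC3)nc2-c2ccc(C)cc2)cc1` shares the core of compound 3 and differs from it only on the amine nitrogen in the ring: 4-nitrophenyl in place of 3-methoxyphenyl on an amine nitrogen in a ring. The step from compound 1 to compound 2 bears on this change, since both steps swap one substituted phenyl on that same ring nitrogen for another, the entering group being 4-chlorophenyl there and 4-nitrophenyl here; the leaving and entering groups differ, however, so the parallel is partial. On this basis a modest lowering of the number is expected, smaller than a large effect but beyond the scatter: the step from compound 3 to compound 4 is estimated at a 2.9-fold lower number from compound 3 to compound 4 (0.46 log units; beyond the scatter). Compound 4 is therefore expected to give 300000 nM in this assay, with a range from 100000 nM to 900000 nM.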

Compound 4, half-maximal inhibitory concentration: 845000 nM
The estimate for compound 4 lay 2.8-fold (0.45 log units) below the measured number; the range from low to high includes it.
By their numbers in this assay, from the lowest: compound 2; then compound 1; then compounds 4 and 3 (each within the scatter of the next).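

In this assay, putting 4-nitrophenyl in place of 3-methoxyphenyl on the amine nitrogen in the ring gives a 1.0-fold lower number from compound 3 to compound 4 (0.01 log units; within the scatter), so these two groups cannot be told apart on this read-out when they sit on this core. The earlier change at the same kind of nitrogen, a 4.7-fold lower number from compound 1 to compound 2 (0.67 log units; beyond the scatter), lay beyond the scatter, which shows that exchanging one substituted phenyl for another at this position does not always move the number: it did so in one pair and not in the other, and the two pairs differ both in the groups exchanged and in their shared core. Nothing given here accounts for this difference between the pairs.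

The compounds shown leave open whether 4-chlorophenyl, carried on the core that bears 3-methoxyphenyl and 4-nitrophenyl, would give a number lower than those two groups do. They also leave open how an unsubstituted phenyl, a 4-aminophenyl or a 4-carboxyphenyl group on that ring nitrogen would read in this assay.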